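This account rests on a few compounds, and the source may have more. Where it says the series, first, only, none or still open, it means among the compounds named here.

Compound 1 `COC(=O)c1cc(-c2cnc(C(=O)CCc3ccc(-c4ccccc4)cc3)o2)ccn1`: 1.5 nM in an assay for inhibition of Fatty-acid amide hydrolase 1 (Rattus norvegicus); a lower number here means a stronger inhibitor, a higher number a weaker inhibitor
Compound 2 `O=C(O)c1cc(-c2cnc(C(=O)CCc3ccc(-c4ccccc4)cc3)o2)ccn1`: 50 nM in this assay

For the measured compounds named here, compound 2 stands highest of the two numbers measured so far; its nearest neighbour, compound 1, sits a 33-fold higher number from compound 1 to compound 2 (1.52 log units; beyond the scatter) away. Compound 3 `O=C(O)c1ccc(-c2cnc(C(=O)CCc3ccc(-c4ccccc4)cc3)o2)nc1` differs from compound 2 by 5-carboxypyridin-2-yl in place of 2-carboxypyridin-4-yl on an aromatic carbon. Going by the values given here, no measured step bears on this rearrangement: the only step known, a 33-fold higher number from compound 1 to compound 2 (1.52 log units; beyond the scatter), concerns the ester against the acid and not where the acid sits on the ring. Compound 3 is therefore expected to stay close to compound 2, an expected step of a 1.2-fold higher number from compound 2 to compound 3 (0.08 log units; within the scatter). The estimated value of compound 3 in this assay is 60 nM, ranging from 10 nM to 400 nM.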

Compound 3, inhibition constant: 14 nM
Estimate against measurement, compound 3: 4.3-fold (0.63 log units) above; low and high end bracket the measured number.
By their numbers in this assay, from the lowest: compound 1; then compound 3; then compound 2.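

Where the carboxylic acid sits on the pyridine ring matters at this place on the core: 5-carboxypyridin-2-yl in place of 2-carboxypyridin-4-yl gives a 3.6-fold lower number from compound 2 to compound 3 (0.55 log units; beyond the scatter) in this assay although the atoms are the same. The moved acid still leaves a 9.3-fold higher number from compound 1 to compound 3 (0.97 log units; beyond the scatter) in this assay so it does not reach the number of the methyl ester. Nothing shown here accounts for the shift.

On these data alone, it remains open whether a methyl ester on the 5-carboxypyridin-2-yl ring would lower the number as it does on the other ring. As far as these compounds go, it is also open how an amide or a primary amine would compare with the acid at this ring position.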